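Cytotoxicity of three measured analogues and one pending

This account rests on a few compounds, and the source may have more. Where it says the series, first, only, none or still open, it means among the compounds named here.

Measured in an ADME assay on cells (Homo sapiens) for cytotoxicity, read by polymerase chain reaction, with a stated time of 3 days; on this read-out lower numbers stand for higher toxicity in this test and higher numbers for lower toxicity in this test:
- compound 1 `Nc1nc(Cl)c(-c2cccs2)c(N[C@@H]2C[C@H](CO)[C@@H](O)[C@H]2O)n1`: > 25000 nM, a limit of the assay, not a number
- compound 2 `CN(C)c1ccc2nc(-c3c(Cl)nc(N)nc3N[C@@H]3C[C@H](CO)[C@@H](O)[C@H]3O)sc2c1`: > 25000 nM, again only a limit
- compound 3 `Cc1nc(NC(C)(C)C)nc(N[C@@H]2C[C@H](CO)[C@@H](O)[C@H]2O)c1-c1nc2ccccc2s1`: 12000 nM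

Compound 3 is the only one of the three with an actual number in this assay; the other two sit at the limit, as the limit of > 25000 nM in this assay, at which 2 of the 3 values shown sit, shows. Compound 4 `Cc1nc(NCc2ccncc2)nc(N[C@@H]2C[C@H](CO)[C@@H](O)[C@H]2O)c1-c1nc2ccccc2s1` differs from compound 3 in one place: (pyridin-4-yl)methyl in place of tert-butyl on a nitrogen on an aromatic ring. For the measured compounds named here, no measured pair isolates such a change, so the step is expected to be small, none beyond the scatter, estimated as a 1.5-fold higher number from compound 3 to compound 4 (0.18 log units; within the scatter). For compound 4 the estimate in this assay is 18000 nM, with a range from 7000 nM to 45000 nM, and a real chance that only a limit is reported.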

Compound 4, half-maximal cytotoxic concentration: 7000 nM
Estimate against measurement, compound 4: 2.6-fold (0.41 log units) above; measured number inside the range.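

In this assay, for the compounds shown here, this is the only measured pair that isolates a change on this nitrogen: (pyridin-4-yl)methyl in place of tert-butyl gives a 1.7-fold lower number from compound 3 to compound 4 (0.23 log units; within the scatter). An aromatic ring and a hydrogen-bond acceptor thus enter at this place with no step beyond the scatter. Like compound 3, compound 4 gives an actual number, so it does not join the values at the limit: the limit of > 25000 nM in this assay, at which 2 of the 4 values shown sit.

Going by these compounds, whether benzyl or a longer alkyl chain on this nitrogen would read the same stays open. So does whether any group here moves the number beyond the scatter.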